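The compounds below may be only part of what the source reports. "The series", "measured", "known", "first", "only" and "open" are said of these compounds alone.

Of the compounds shown here, three built on a shared core have been measured in a functional assay on HEK293T cells for agonist activity at histamine H2 receptor (Homo sapiens), read by beta-arrestin recruitment; on this read-out lower numbers stand for an effect already at smaller amounts and higher numbers for an effect only at larger amounts of compound. Compound 1 `Cc1nc(N)sc1CCCN/C(N)=N/C(=O)NC(C)c1cccc(F)c1` gives 64.6 nM in this assay. Compound 2 `CCCCCNC(=O)/N=C(\N)NCCCc1sc(N)nc1C` gives 178 nM, and compound 3 `N/C(=N\C(=O)NCc1ccccc1)NC1CCc2nc(N)sc2C1` gives 4370 nM. Among these three numbers compound 2 stands second highest: its nearest neighbour is compound 1, whose lower number lies beyond the usual scatter of repeated measurements, and its furthest is compound 3, whose much higher number lies far beyond it.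

Compound 4 `CCCNC(=O)/N=C(\N)NCCCc1sc(N)nc1C` has not yet been measured. It differs from compound 2 in a single place: hydrogen in place of ethyl on a saturated chain carbon, three bonds along the chain from an amide-type nitrogen. For the measured compounds named here, no pair of measured compounds shows this same change, so there is no measured step to lean on, and the chain in question is the only part that moves. The step from compound 2 to compound 4 is expected to be modest, a 1.8-fold higher number from compound 2 to compound 4 (0.25 log units; within the scatter), leaning toward a higher number and sitting near the edge of the scatter. Compound 4 is estimated at 320 nM, with a range from 130 nM to 900 nM.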

Compound 4, half-maximal effective concentration: 170 nM
Compound 4: the middle estimate sits 1.9-fold (0.27 log units) above what was measured; measured number inside the range.
By their numbers in this assay, from the lowest: compound 1; then compounds 4 and 2 (each within the scatter of the next); then compound 3.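

Putting hydrogen in place of ethyl on a saturated chain carbon, three bonds along the chain from an amide-type nitrogen, turns the pentyl chain into a propyl chain and gives, in this assay, a 1.0-fold lower number from compound 2 to compound 4 (0.02 log units; within the scatter). For the compounds shown here, this is the first direct look at this position, and on this read-out the two compounds cannot be told apart, even with 2 carbon atoms gone from the chain. Nothing measured here explains why the two numbers lie so close.

Open, going by these compounds, is how the number would respond to a shorter chain such as ethyl or methyl, to a longer chain such as heptyl, or to an amine or a carboxylic acid at the chain end. One pair also cannot show whether the same change would read alike on the core of compound 3.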